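Pyridin-2-yl for 4-bromophenyl on the shared core

The source may report more compounds than this note shows. Statements on the series, on what has been measured and on what is new or still open speak of the compounds shown alone.

Measured so far:
Compound 1 `C=C1C[C@]23C[C@@]1(O)CC[C@H]2c1ccc(O)c(C)c1[C@@H]3Cn1cc(-c2ccccn2)nn1`: > 20000 nM, a limit of the assay.
Compound 2 `C=C1C[C@]23C[C@@]1(O)CC[C@H]2c1ccc(O)c(C)c1[C@@H]3Cn1cc(-c2ccc(Br)cc2)nn1`: > 20000 nM, a limit of the assay.
Compound 3 `C=C1C[C@]23C[C@@]1(O)CC[C@@H]2c1cccc(C)c1[C@@H]3Cn1cc(-c2ccc(Br)cc2)nn1`: > 20000 nM, a limit of the assay.

All three values come from a functional assay on SW480 cells (Homo sapiens) for cytotoxicity, read by MTT assay, with a stated time of 4 days; a lower number here means a stronger inhibitor, a higher number a weaker inhibitor. None of them is a number, so no order among the three compounds can be read. The change pyridin-2-yl in place of 4-bromophenyl on an aromatic carbon gives a step that the two limits leave unreadable from compound 2 to compound 1. How the core of compound 3 differs from the core of compound 2 is not broken down here. Compound 4 `C=C1C[C@]23C[C@@]1(O)CC[C@@H]2c1cccc(C)c1[C@@H]3Cn1cc(-c2ccccn2)nn1` carries the same change on the core of compound 3: pyridin-2-yl in place of 4-bromophenyl on an aromatic carbon. The place lines of the two changes agree word for word, so this is the same change made a second time. All that is known rests on (the limit of > 20000 nM in this assay, at which 3 of the 3 values shown sit), and compound 3 itself stands at that limit.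

Compound 4 is therefore expected to move by about a step that the limit leaves unreadable from compound 3 to compound 4 in this assay. The expected value of compound 4 is 30000 nM, estimated to fall between 12000 nM and 100000 nM, most likely reported again only as a limit.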

Compound 4, half-maximal inhibitory concentration: > 20000 nM
Compound 4 was reported as a limit (the forecaster's own chance of this, stated with the estimate: 85%); the middle value is on the limit's open side.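

Compound 4 in this assay gives > 20000 nM as a limit of the assay and not a number. Compound 3 also stands at a limit, so no step can be read between compound 3 and compound 4. The compounds shown leave open what pyridin-2-yl in place of 4-bromophenyl does on either core, since none has a readable value: the limit of > 20000 nM in this assay, at which 4 of the 4 values shown sit.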